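The source may hold more compounds than are shown below. What is called first, only, known or untested is meant among the compounds shown, and "the series" means these compounds.

Compound 1 `C1=CC[C@]23CC=CC[C@@]2(C1)CNC3`: > 100000 nM
Compound 2 `C1CC[C@]23CCCC[C@@]2(C1)CNC3`: > 100000 nM
Compound 3 `C1=CC[C@]23CCC[C@@]2(C1)CNC3`: > 100000 nM

All three measured compounds share a rigid, fused tricyclic core carrying an amine nitrogen in a ring, and differ only in how many double bonds the carbon rings hold. In an ADME assay on MDCK cells (Canis lupus familiaris) for cytotoxicity, read by microscopy (a higher number here means that more compound is tolerated, a lower number that less compound is tolerated), compound 1 gives > 100000 nM, which is a limit of the assay rather than a number. In this assay compound 2 likewise gives > 100000 nM, again a limit. Compound 3, the starting point here, gives > 100000 nM in this assay, once more a limit. So compound 3 stands exactly where its two neighbours stand: the limit of > 100000 nM in this assay, at which 3 of the 3 values shown sit.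

The next compound, compound 4 `N=C(N)N1C[C@@]23CC=CC[C@@]2(CCC3)C1`, carries a group of 3 heavy atoms (1 carbon, 2 nitrogen; no ring) in place of a hydrogen atom, on an amine nitrogen in a ring. Among the compounds with values here, since no measured pair shows a step for this kind of change, there is no direct guide to its size. With every measured compound sitting at the limit, the expectation in this assay is for no step beyond the scatter, so the step from compound 3 to compound 4 is expected to be about a number no higher from compound 3 to compound 4 (the limit leaves the size open). Compound 4 is therefore estimated at 100000 nM, with a range from 30000 nM to 100000 nM, most likely again reported only as a limit.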

Compound 4, minimum cytotoxic concentration: > 100000 nM
Compound 4: no number, only a limit; the forecaster's own chance of this, stated with the estimate: 75%; the middle value lies on the limit itself.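

Compound 3 and compound 4 both end at a limit rather than a number, so the step between them cannot be read, and the whole set looks the same: the limit of > 100000 nM in this assay, at which 4 of the 4 values shown sit.

The compounds shown leave open how much of any of them the cells would tolerate, and whether the added group changes that tolerance at all.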